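The compounds below may be only part of what the source reports. "The series", "measured", "known", "first", "only" and "open" are said of these compounds alone.

Of the compounds shown here, two built on a shared core have been tested in a functional assay on SMMC-7721 cells (Homo sapiens) for antiproliferative activity, read by MTT assay, with a stated time of 48 h; a higher number here means a weaker inhibitor, a lower number a stronger inhibitor. Compound 1 `CO[C@]1(C)/C=C/C(=O)/C(CO)=C\C[C@](C)(CCC=C(C)C)/C=C/[C@H]1OC(=O)C=C(C)C` gives 15800 nM in this assay, and compound 2 `CC(C)=CCC[C@]1(C)/C=C/[C@@H](OC(=O)C=C(C)C)[C@](C)(O)/C=C/C(=O)/C(CN(C)C)=C\C1` gives 820 nM. Compound 2 thus holds the lower of the two numbers, and its gap to compound 1 is wide enough to lie beyond the usual scatter of repeated runs; the two structures differ in more than one place, so that gap cannot be tied to any single change.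

Compound 3 `CO/N=C/C1=C/C[C@](C)(CCC=C(C)C)/C=C/[C@@H](OC(=O)C=C(C)C)[C@](C)(O)/C=C/C1=O` has not been measured. It differs from compound 2 at one spot, on a double-bonded ring carbon: a group of 4 heavy atoms (2 carbon, 1 nitrogen, 1 oxygen; no ring) in place of a group of 4 heavy atoms (3 carbon, 1 nitrogen; no ring), on a double-bonded ring carbon

Within the data shown here, no measured pair isolates this kind of exchange, so the direction must be judged from what is at hand. Compound 2 gives 820 nM, the lowest number shown, and no other measured compound carries the (dimethylamino)methyl group. The step is therefore expected to go upward, toward weaker inhibition, by about a 6.1-fold higher number from compound 2 to compound 3 (0.79 log units; beyond the scatter), more than the scatter yet short of the distance to compound 1. For compound 3 the estimated value in this assay is 5000 nM, with a likely range from 1500 nM to 20000 nM.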

Compound 3, half-maximal inhibitory concentration: 3470 nM
For compound 3 the middle estimate is 1.4-fold (0.16 log units) above the measured one; the range from low to high includes it.
By their numbers in this assay, from the lowest: compound 2; then compound 3; then compound 1.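

In this assay, the exchange at this double-bonded ring carbon gives a 4.2-fold higher number from compound 2 to compound 3 (0.63 log units; beyond the scatter), a modest step but one beyond the scatter. The (dimethylamino)methyl group leaves and a group of the same size, 4 heavy atoms, enters; this group has an oxygen and a nitrogen and a double bond outside aromatic rings, so heavy-atom count alone does not set the number at this position, and this pair, unlike compounds 1 and 2, ties a change in activity to one place on the shared core. Nothing measured here speaks to why the number rises with this exchange.

The compounds shown leave open whether the nitrogen of compound 2 matters as such, which a plain aminomethyl group, a pyrrolidin-1-ylmethyl group or a morpholin-4-ylmethyl group at the same carbon could help to settle. They also leave open whether a longer chain carrying the same dimethylamino group would hold, improve or lose activity, and whether this exchange would go the same way on a compound that differs elsewhere on the core.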